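Removing One Ester Group: What Compound 4 Should Show

The compounds below may be only part of what the source reports. "The series", "measured", "known", "first", "only" and "open" are said of these compounds alone.

Among the measured compounds shown here, compound 3 `C=C1C(=O)O[C@H]2[C@H]1[C@@H](OC(=O)/C(C)=C/C)C[C@@](C)(O)[C@]13C=C[C@](C)([C@H]21)[C@]1(C3)C(=O)O[C@@H]2[C@H]3C(C)=CC[C@H]3[C@](C)(O)C[C@H](OC(=O)/C(C)=C/C)[C@H]21` is the only compound of this set with a measured number: in a functional assay on CNE cells (Homo sapiens) for cytotoxicity, read by MTT assay, with a stated time of 48 h (on this read-out higher numbers stand for weaker inhibition and lower numbers for stronger inhibition), compound 3 gives 4600 nM. Compound 1 `C=C1C(=O)O[C@@H]2[C@@H]3[C@@]4(C=C[C@@]3(C)[C@]3(C4)C(=O)O[C@@H]4[C@H]5C(C)=CC[C@H]5[C@](C)(O)C[C@H](O)[C@H]43)[C@](C)(O)CC[C@@H]12` reaches only a limit of the assay, giving > 10000 nM. Compound 2 `C=C1C(=O)O[C@H]2[C@H]1[C@@H](OC(=O)/C(C)=C/C)C[C@@](C)(O)[C@]13C=C[C@](C)([C@H]21)[C@]1(C3)C(=O)O[C@@H]2[C@H]3C(C)=CC[C@H]3[C@](C)(O)C[C@H](O)[C@H]21` likewise sits at a limit, with > 10000 nM. Compound 4 `C=C1C(=O)O[C@@H]2[C@@H]3[C@@]4(C=C[C@@]3(C)[C@]3(C4)C(=O)O[C@@H]4[C@H]5C(C)=CC[C@H]5[C@](C)(O)C[C@H](OC(=O)/C(C)=C/C)[C@H]43)[C@](C)(O)CC[C@@H]12` is not yet measured; it differs from compound 3 by hydrogen in place of ((1-methylprop-1-en-1-yl)carbonyl)oxy on a saturated ring carbon. This is the reverse of the step that the two limits leave unreadable from compound 1 to compound 2, whose size the two limits hide, and compound 4 stands to compound 1 as compound 3 stands to compound 2, a step of an at least 2.1-fold lower number from compound 2 to compound 3 (0.33 log units; beyond the scatter). The limits leave the first step unreadable, so the direction for compound 4 is uncertain, but because the limit of > 10000 nM in this assay, at which 2 of the 3 values shown sit, shows most of the set beyond the upper limit, a somewhat higher number than that of compound 3 is expected. Compound 4 is therefore estimated at 8000 nM, between 3000 nM and 20000 nM, which corresponds to an expected step of a 1.7-fold higher number from compound 3 to compound 4 (0.24 log units; within the scatter).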

Compound 4, half-maximal inhibitory concentration: > 10000 nM
Compound 4: a limit, no number (the forecaster's own chance of this, stated with the estimate: 45%); middle value at least 1.2-fold (0.09 log units) from the limit.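

In this assay, removing the ((1-methylprop-1-en-1-yl)carbonyl)oxy group from this saturated ring carbon gives an at least 2.1-fold higher number from compound 3 to compound 4 (0.33 log units; beyond the scatter), so the ester here matters for the cytotoxic effect. Among the compounds shown here, until now, the only readable change was at the other ester, on an oxygen: an at least 2.1-fold lower number from compound 2 to compound 3 (0.33 log units; beyond the scatter). Of these compounds, only compound 3 carries both esters and gives a number, while the other three stop at a limit of the assay: the limit of > 10000 nM in this assay, at which 3 of the 4 values shown sit.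

From the compounds shown here alone, the steps among compound 1, compound 2 and compound 4 cannot be read, so it remains unknown whether either single ester contributes anything on its own. Also open, going by these compounds, is whether a smaller acetyl ester or an amine on this ring carbon would keep the effect seen with compound 3.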